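The source may report more compounds than this note shows. Statements on the series, on what has been measured and on what is new or still open speak of the compounds shown alone.

In a functional assay on K562 cells (Homo sapiens) for antiproliferative activity, with a stated time of 72 h (a lower number here means a stronger inhibitor, a higher number a weaker inhibitor), compound 1 `Cc1ccc(CNc2ncnc3c2ncn3[C@@H]2O[C@H](CO)[C@@H](O)[C@H]2O)cc1` reaches only a limit, > 166000 nM. Compound 2 `OC[C@H]1O[C@@H](n2cnc3c(NCc4ccc(F)cc4F)ncnc32)[C@H](O)[C@@H]1O` gives 9600 nM. Compound 3 `OC[C@H]1O[C@@H](n2cnc3c(NCc4ccc(F)cc4Cl)ncnc32)[C@H](O)[C@@H]1O` gives 15600 nM, the higher of the two real numbers, yet the gap to compound 2 is small: a 1.6-fold higher number from compound 2 to compound 3 (0.21 log units; within the scatter). The decisive steps are those leaving the 4-methylphenyl group: an at least 17-fold lower number from compound 1 to compound 2 (1.23 log units; beyond the scatter) and an at least 10-fold lower number from compound 1 to compound 3 (1.02 log units; beyond the scatter), both large, though each is measured only against the limit (the limit of > 166000 nM in this assay, at which 1 of the 3 values shown sits). Compound 4 `OC[C@H]1O[C@@H](n2cnc3c(NCc4ccc(C(F)(F)F)cc4)ncnc32)[C@H](O)[C@@H]1O` arises by 4-(trifluoromethyl)phenyl in place of 2-chloro-4-fluorophenyl on a saturated chain carbon bound to a nitrogen on an aromatic ring. Among the compounds with values here, no measured step covers a trifluoromethyl group, so the expectation leans on compound 1's limit and the halogen results; a moderate rise is expected, a 1.9-fold higher number from compound 3 to compound 4 (0.28 log units; within the scatter). Compound 4 is therefore estimated at 30000 nM, between 8000 nM and 120000 nM.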

Compound 4, half-maximal inhibitory concentration: > 166000 nM
Compound 4 was reported as a limit; the forecaster's own chance of this, stated with the estimate: 25%; at least 5.5-fold (0.74 log units) between middle value and limit.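

In this assay the change to 4-(trifluoromethyl)phenyl on a saturated chain carbon bound to a nitrogen on an aromatic ring gives an at least 10-fold higher number from compound 3 to compound 4 (1.02 log units; beyond the scatter) and an at least 17-fold higher number from compound 2 to compound 4 (1.23 log units; beyond the scatter) on leaving the two halogen-bearing groups. Fluorine alone is thus not enough: of these four compounds, only the two with two halogens on the phenyl ring give real numbers. The value of compound 4 is a limit, shared with compound 1: the limit of > 166000 nM in this assay, at which 2 of the 4 values shown sit.

The step from compound 1 to compound 4 cannot be read. Going by these compounds, whether a phenyl ring carrying a single chloro, an amine or a carboxylic acid would give a real number stays open.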